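Removing the Side Chain from Compound 1

A few compounds are considered here, and "the series" means these few. Any claim that something is new, unique, unknown or untested is made for them only; others in the source may bear on it.

In a functional assay on THP-1 cells (Homo sapiens) for inhibition, read by sulforhodamine B assay, with a stated time of 48 h (a lower number here means a stronger inhibitor, a higher number a weaker inhibitor), compound 1 (`COc1ccc(C(c2ccc(OC(C)CN(C)C)cc2)c2cccc3ccccc23)c(OC)c1OC`) gives 15000 nM. Compound 3 (`COc1ccc(/C(=C/c2ccc(F)cc2)c2cccc3ccccc23)c(OC)c1OC`) gives 18900 nM, and these two numbers lie within the scatter of each other. Compound 2 (`C=CCC(O)(c1ccc(OC)c(OC)c1OC)c1cccc2ccccc12`) is reported only as a limit of the assay, > 20000 nM.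

Compound 4 (`COc1ccc(C(c2ccc(O)cc2)c2cccc3ccccc23)c(OC)c1OC`) has hydrogen in place of 1-((dimethylamino)methyl)ethyl on an oxygen on an aromatic ring. Within the data shown here, no measured pair isolates this change. Compound 3 also lacks this group and gives 18900 nM, so only a small step towards weaker inhibition, perhaps none beyond the scatter, is expected: a 1.3-fold higher number from compound 1 to compound 4 (0.12 log units; within the scatter). For compound 4 the estimated value is 20000 nM, with an expected range from 9000 nM to 35000 nM.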

Compound 4, half-maximal inhibitory concentration: 9450 nM
Compound 4: the middle estimate sits 2.1-fold (0.33 log units) above what was measured, and the stated range covers the measured number.
By their numbers in this assay, from the lowest: compounds 4, 1 and 3 (each within the scatter of the next). At a limit, above all of these: compound 2.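

In this assay, putting hydrogen in place of 1-((dimethylamino)methyl)ethyl on this oxygen gives a 1.6-fold lower number from compound 1 to compound 4 (0.20 log units; within the scatter). Among these compounds, this is the first pair to isolate the change, and it shows that the side chain, with its amine, is not needed to keep the number at this level. Nothing measured here gives a reason for this step.

Still open, going by these compounds, is whether a different group on this oxygen, such as methyl, a longer amine chain or a carboxylic acid, would move the number beyond the scatter.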